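A few compounds are considered here, and "the series" means these few. Any claim that something is new, unique, unknown or untested is made for them only; others in the source may bear on it.

Measured values in a functional assay on MGC-803 cells (Homo sapiens) for inhibition, read by MTT assay, with a stated time of 48 h; on this read-out lower numbers stand for stronger inhibition and higher numbers for weaker inhibition:
compound 1 `COc1ccc(CN(C(C)=O)c2cc(OC)c(OC)c(OC)c2)cc1O` — 79 nM
compound 2 `COc1ccc(CN(C(=O)C(C)Br)c2cc(OC)c(OC)c(OC)c2)cc1O` — 120 nM
compound 3 `C=C(C)C(=O)N(Cc1ccc(OC)c(O)c1)c1cc(OC)c(OC)c(OC)c1` — 390 nM

Compound 3 gives the highest number of the three in this assay; the nearest is compound 2 and the furthest compound 1, both gaps lying beyond the scatter. The steps reaching compound 3 are a 4.9-fold higher number from compound 1 to compound 3 (0.69 log units; beyond the scatter) and a 3.3-fold higher number from compound 2 to compound 3 (0.51 log units; beyond the scatter), each a modest rise, whereas a 1.5-fold higher number from compound 1 to compound 2 (0.18 log units; within the scatter) stays within the scatter.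

Compound 4 `C/C=C/C=C/C(=O)N(Cc1ccc(OC)c(O)c1)c1cc(OC)c(OC)c(OC)c1` differs from compound 3 in one place: penta-1,3-dien-1-yl in place of 1-methylethenyl on a carbonyl carbon. For the measured compounds named here, no measured step swaps one unsaturated group on the carbonyl carbon for another; the two steps that bear on the position only show that the 1-methylethenyl group raised the number against methyl and against 1-bromoethyl. Going by the values given here, the penta-1,3-dien-1-yl group has no precedent, so the direction of the step is uncertain. The series gives no reason to expect a return toward the number of compound 1, and a value near or somewhat above that of compound 3 is the working expectation. For compound 4 the expected step is a 1.4-fold higher number from compound 3 to compound 4 (0.15 log units; within the scatter). The estimate for compound 4 in this assay is 550 nM, with a range of 200 nM to 1500 nM.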

Compound 4, half-maximal inhibitory concentration: 140 nM
Estimate against measurement, compound 4: 3.9-fold (0.59 log units) above; the whole stated range lies above it.
By their numbers in this assay, from the lowest: compounds 1, 2 and 4 (each within the scatter of the next); then compound 3.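

Within this assay, a 2.8-fold lower number from compound 3 to compound 4 (0.44 log units; beyond the scatter), so a double bond on the carbonyl carbon does not by itself go with the weaker inhibition seen for compound 3, and the position accepts the larger penta-1,3-dien-1-yl group. Against the saturated groups, a 1.2-fold higher number from compound 2 to compound 4 (0.07 log units; within the scatter) and a 1.8-fold higher number from compound 1 to compound 4 (0.25 log units; within the scatter), which places compound 4 with compounds 1 and 2 and leaves compound 3 as the only one of the four set apart at this position. Nothing available bears on the reason for this difference between the two unsaturated groups.

An unbranched ethenyl group would help show whether the raised number of compound 3 goes with the methyl branch of 1-methylethenyl or with the short unsaturated group as a whole, and a saturated pentyl chain would test whether the double bonds of penta-1,3-dien-1-yl matter at all. Also open, from the compounds shown here alone, is how far the position accepts a phenyl ring or a chain ending in an amine or a carboxylic acid on the carbonyl carbon.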